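This account rests on a few compounds, and the source may have more. Where it says the series, first, only, none or still open, it means among the compounds named here.

Three compounds were measured in an ADME assay on RAW264.7 cells (Mus musculus) for cytotoxicity, read by MTT assay, with a stated time of 24 h; a higher number here means that more compound is tolerated, a lower number that less compound is tolerated:

Compound 1 `O=c1oc2ccccc2c(=O)n1-c1ccc(Cl)cc1F`: 24400 nM
Compound 2 `O=c1oc2ccc(I)cc2c(=O)n1-c1ccc(Cl)cc1F`: 8900 nM
Compound 3 `O=c1oc2ccc(I)cc2c(=O)n1-c1ccc(I)cc1F`: 7600 nM

Compound 4 `O=c1oc2ccccc2c(=O)n1-c1ccc(I)cc1F` has not yet been measured. It differs from compound 3 in one place: hydrogen in place of iodo on an aromatic carbon. The same change separates compound 2 from compound 1, (hydrogen in place of iodo on an aromatic carbon), and there it gave a modest step, a 2.7-fold higher number from compound 2 to compound 1 (0.44 log units; beyond the scatter). The cores of compound 2 and compound 3 differ by iodo in place of chloro on an aromatic carbon, a change that gave a 1.2-fold lower number from compound 2 to compound 3 (0.07 log units; within the scatter), so the two pairs sit on closely similar cores. In this assay compound 4 is therefore expected to move from compound 3 by about a 2.6-fold higher number from compound 3 to compound 4 (0.42 log units; beyond the scatter), because the earlier step of a 2.7-fold higher number from compound 2 to compound 1 (0.44 log units; beyond the scatter) was made by the same change on a near-identical core. For compound 4 the estimate is 20000 nM, with a likely range from 9500 nM to 42000 nM.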

Compound 4, half-maximal cytotoxic concentration: 24500 nM
Beside the measured number, compound 4's estimate is 1.2-fold (0.09 log units) below it; the measured number falls inside the stated range.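

In this assay, hydrogen in place of iodo on an aromatic carbon gave a 3.2-fold higher number from compound 3 to compound 4 (0.51 log units; beyond the scatter), which agrees with the step made by that change on the other core: the same change on two cores in this assay, a 2.7-fold higher number (0.44 log units; beyond the scatter) from compound 2 to compound 1 and a 3.2-fold higher number (0.51 log units; beyond the scatter) from compound 3 to compound 4, 1.2-fold (0.07 log units) apart, within the scatter of two such steps. Iodo in place of chloro on an aromatic carbon gave a 1.0-fold higher number from compound 1 to compound 4 (0.00 log units; within the scatter), and this change also carries over between cores: the same change on two cores in this assay, a 1.2-fold lower number (0.07 log units; within the scatter) from compound 2 to compound 3 and a 1.0-fold higher number (0.00 log units; within the scatter) from compound 1 to compound 4, 1.2-fold (0.07 log units) apart, within the scatter of two such steps. Each change therefore behaves alike on the two cores tested here, but two cores per change are a narrow test, and these numbers do not show why the steps agree or whether they would hold on other cores.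

Going by these compounds, whether a methoxy group, an amine or a carboxylic acid in place of the iodo group would give a similar step remains open.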